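Cyclopropylaminomethyl in place of carbamoyl on compound 2

This account rests on a few compounds, and the source may have more. Where it says the series, first, only, none or still open, it means among the compounds named here.

Compound 2 `Cn1nc2c(=O)n(CC3(O)CCN(Cc4ccc(-c5ccco5)cc4Cl)CC3)cnc2c1-c1ccc(C(N)=O)cc1` gives the lowest number of the three measured compounds in an assay on isolated protein for inhibition of ubiquitin carboxyl-terminal hydrolase 7 (Homo sapiens), with stated times of 30 min and 2 h (on this read-out lower numbers stand for stronger inhibition and higher numbers for weaker inhibition), at 80.8 nM. Compound 1 `Cn1nc2c(=O)n(CC3(O)CCN(Cc4ccc(-c5n[nH]c(=O)o5)cc4Cl)CC3)cnc2c1-c1ccc(CN)cc1` gives 171 nM and compound 3 `Cn1nc2c(=O)n(CC3(O)CCN(Cc4ccc(-c5ccc(C(=O)O)o5)cc4Cl)CC3)cnc2c1-c1ccc(CN)cc1` gives 753 nM. Compound 4 `Cn1nc2c(=O)n(CC3(O)CCN(Cc4ccc(-c5ccco5)cc4Cl)CC3)cnc2c1-c1ccc(CNC2CC2)cc1` differs from compound 2 by (cyclopropylamino)methyl in place of carbamoyl on an aromatic carbon. Within the data shown here, no measured step touches this position: the only one-place step, a 4.4-fold higher number from compound 1 to compound 3 (0.64 log units; beyond the scatter), concerns a different ring. Among the measured compounds shown here, compound 1 and compound 2 differ at this position and elsewhere, so their two values show only that an aminomethyl-bearing analogue stays in the same region. A step within or near the scatter is therefore expected, a 1.4-fold higher number from compound 2 to compound 4 (0.13 log units; within the scatter), with no firm direction. For compound 4 the expected value in this assay is 110 nM, between 35 nM and 350 nM.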

Compound 4, half-maximal inhibitory concentration: 54.1 nM
For compound 4 the middle estimate is 2.0-fold (0.31 log units) above the measured one; low and high end bracket the measured number.
By their numbers in this assay, from the lowest: compounds 4 and 2 (each within the scatter of the next); then compound 1; then compound 3.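

In this assay, the position on the aromatic carbon para to a large group accepts a swap of carbamoyl for (cyclopropylamino)methyl with no change that can be read: a 1.5-fold lower number from compound 2 to compound 4 (0.17 log units; within the scatter). The earlier compounds shown here never isolated this position, and here the carbonyl leaves and a three-membered ring of carbon enters without moving the number beyond the scatter. The data offer nothing that explains this tolerance. The compounds shown leave open how a nitrile or a longer amine chain would read at this position. They also leave open whether (cyclopropylamino)methyl behaves alike when the furan ring carries a carboxylic acid.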